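The source may report more compounds than this note shows. Statements on the series, on what has been measured and on what is new or still open speak of the compounds shown alone.

Measured compounds:
compound 1 `NC(=O)CC[C@H](NC(=O)CN(c1ncnc2c1ncn2C1CCCCO1)C1CC1)C(=O)OCc1ccccc1`, 39.4%
compound 2 `CC[C@H](C)[C@H](NC(=O)CN(c1nc(Cl)nc2[nH]cnc12)C1CC1)C(=O)OCc1ccccc1`, 40.6%

In a functional assay on the whole organism (Tail, strain ICR) with Mus musculus as the target, in the tail flick test, with a stated time of 60 min, at a dose of 25 umol/kg by the oral route (on this read-out lower numbers stand for a weaker effect and higher numbers for a stronger effect at the one dose given), compound 1 gives 39.4% and compound 2 gives 40.6%; the gap between them lies within the scatter, so the two stand level and neither can be ranked over the other. Among the measured compounds shown here, no pair of measured compounds differs in one place, so no step size is available as a guide. Compound 3 `CSCC[C@H](NC(=O)CN(c1ncnc2c1ncn2C1CCCCO1)C1CC1)C(=O)OCc1ccccc1` differs from compound 1 by methylsulfanyl in place of carbamoyl on a saturated chain carbon, three bonds along the chain from an amide-type nitrogen and a carbonyl carbon. With nothing to anchor the change, the step from compound 1 to compound 3 is expected to be no larger than the scatter, a number 2.6 percentage points higher from compound 1 to compound 3 (within the scatter). Compound 3 is therefore estimated at 42% in this assay, between 25% and 60%.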

Compound 3, a percentage reported as activity, at one dose (the size of the read-out at that dose, not a potency): 41%
Compound 3: middle estimate off by 1 percentage points, on the high side; low and high end bracket the measured number.
By their numbers in this assay, from the lowest: compounds 1, 2 and 3 (each within the scatter of the next).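

In this assay, methylsulfanyl in place of carbamoyl on this saturated chain carbon gives a number 1.6 percentage points higher from compound 1 to compound 3 (within the scatter). Among the compounds shown here, this is the first sign that the position tolerates a change of group: the hydrogen-bond donor of carbamoyl is lost, yet the step stays within the scatter. No evidence bearing on this result is available. From the compounds shown here alone, it remains open whether a carboxylic acid, an amine or a longer chain at this position would also stand level with compound 1. Going by these compounds, it is equally open whether the same change would read alike on a different core.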